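Cytotoxicity notes on two measured analogues and one pending

The source may hold more compounds than are shown below. What is called first, only, known or untested is meant among the compounds shown, and "the series" means these compounds.

Measured so far:
compound 1 `CCCc1ccsc1CN[C@@H]1C[C@H]2C[C@@H]([C@H]1C)C2(C)C` with 50000 nM
compound 2 `C[C@H]1[C@H](NCc2ccc(Br)s2)C[C@H]2C[C@@H]1C2(C)C` with 43000 nM

In an ADME assay on MDCK cells (Canis lupus familiaris) for cytotoxicity, read by microscopy, with a stated time of 48 h (a lower number here means that less compound is tolerated, a higher number that more compound is tolerated), compound 1 gives 50000 nM, and compound 2 gives 43000 nM; the two values lie within the scatter of each other, so no order between them is claimed. Compound 3 `C[C@H]1[C@H](NCc2sccc2C2CC2)C[C@H]2C[C@@H]1C2(C)C` has not yet been measured in this assay. It differs from compound 1 by cyclopropyl in place of propyl on an aromatic carbon. Among the compounds with values here, no step between measured compounds is known for this assay, so the expectation rests on compound 1 alone. Compound 3 is expected to give a step of a 1.1-fold lower number from compound 1 to compound 3 (0.05 log units; within the scatter), none beyond the scatter. Compound 3 is estimated at 45000 nM, with a range from 20000 nM to 100000 nM.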

Compound 3, minimum cytotoxic concentration: 25000 nM
Compound 3: the middle estimate sits 1.8-fold (0.26 log units) above what was measured; low and high end bracket the measured number.
By their numbers in this assay, from the lowest: compounds 3, 2 and 1 (each within the scatter of the next).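

The first step read at this position in this assay, cyclopropyl in place of propyl on an aromatic carbon, stands at a 2.0-fold lower number from compound 1 to compound 3 (0.30 log units; within the scatter) and so does not separate the two compounds beyond the scatter. With the same count of carbons, a three-membered ring at this place therefore gives a tolerated concentration that cannot be told apart from that of the open propyl chain. No measured evidence bears on the reason for this step.

As far as these compounds go, whether a longer chain, an amine or a carboxylic acid at this place would also stay within the scatter of compound 1 remains open. So does whether cyclopropyl in place of propyl would read the same way elsewhere on the ring.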